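Difluoromethyl in place of 1-hydroxy-1-methylethyl: compound 3

The source may hold more compounds than are shown below. What is called first, only, known or untested is meant among the compounds shown, and "the series" means these compounds.

Among the compounds with values here, compound 2 `CC(=O)NCc1cccc(Cn2nc(NS(=O)(=O)c3ccc(Cl)s3)c3c(C(C)(C)O)cccc32)c1` stands highest of the two numbers measured so far, giving 100 nM in a functional assay on CHO cells for antagonist activity at C-C chemokine receptor type 4 (Homo sapiens), read by GTPgammaS binding; a lower number here means a stronger inhibitor, a higher number a weaker inhibitor; its nearest neighbour, compound 1 `CC(=O)NCc1cccc(Cn2nc(NS(=O)(=O)c3ccc(Cl)s3)c3c(C(C)O)cccc32)c1`, gives 20 nM in this assay. Within the data shown here, the single measured step, a 5.0-fold higher number from compound 1 to compound 2 (0.70 log units; beyond the scatter), shows that this position on the shared core moves the number by a modest amount. Compound 3 `CC(=O)NCc1cccc(Cn2nc(NS(=O)(=O)c3ccc(Cl)s3)c3c(C(F)F)cccc32)c1` carries difluoromethyl in place of 1-hydroxy-1-methylethyl on an aromatic carbon, the new group standing ortho to a fused ring, part of a fused or bridged system of two rings. Among the measured compounds shown here, no measured step swaps the whole group, so the direction is uncertain. Compound 3 is expected to come in near compound 2, with a step of a 1.7-fold lower number from compound 2 to compound 3 (0.22 log units; within the scatter). The estimate for compound 3 is 60 nM, within 15 nM to 250 nM.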

Compound 3, half-maximal inhibitory concentration in the C-C chemokine receptor type 4 assay: 100 nM
Estimate against measurement, compound 3: 1.7-fold (0.22 log units) below; the range from low to high includes it.
By their numbers in the C-C chemokine receptor type 4 assay, from the lowest: compound 1; then compounds 2 and 3 (each within the scatter of the next).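

In the C-C chemokine receptor type 4 assay, replacing 1-hydroxy-1-methylethyl with difluoromethyl gives no change at the digits printed from compound 2 to compound 3 (within the scatter), so a group with no hydrogen-bond donor or acceptor on this aromatic carbon matches the tertiary alcohol, while 1-hydroxyethyl keeps its lead, with a 5.0-fold higher number from compound 1 to compound 3 (0.70 log units; beyond the scatter). In a physicochemical assay for solubility, read by chemiluminescence, measured as kinetic solubility (on this read-out lower numbers stand for lower solubility and higher numbers for higher solubility), compound 2 gives >= 159 ug/mL, which is a limit. In the physicochemical assay compound 3 gives >= 188 ug/mL, also a limit, so the step to this compound cannot be read.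

On these data alone, whether a methoxy group or an amine on this carbon would match 1-hydroxyethyl in the C-C chemokine receptor type 4 assay stays open.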